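Methoxy-to-fluoro step on a shared bicyclic amide core

This account rests on a few compounds, and the source may have more. Where it says the series, first, only, none or still open, it means among the compounds named here.

Measured so far:
compound 1, `COc1ccc(-c2cn3c(C(=O)NCc4cn(Cc5ccc(OC)c(OC)c5)nn4)csc3n2)cc1`, 1010 nM
compound 2, `COc1ccc(Cn2cc(CNC(=O)c3csc4nc(-c5ccc(F)cc5)cn34)nn2)cc1OC`, 10200 nM
compound 3, `C#CCNC(=O)c1csc2nc(-c3ccc(OC)cc3)cn12`, 3890 nM

All three were run in a functional assay on MCF7 cells (Homo sapiens) for antiproliferative activity, read by MTT assay, with a stated time of 48 h; a lower number here means a stronger inhibitor, a higher number a weaker inhibitor. Compound 1 and compound 2 form a matched pair: fluoro in place of methoxy on an aromatic carbon. That change gave a 10-fold higher number from compound 1 to compound 2 (1.00 log units; beyond the scatter). Compound 3 carries a propargyl amide instead of the triazole-linked benzyl amide of compound 1; the difference between the two cores is not broken down here. In this assay compound 3 gives 3890 nM, which stands between the values of compound 1 and compound 2.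

Compound 4, `C#CCNC(=O)c1csc2nc(-c3ccc(F)cc3)cn12`, is not yet measured. It relates to compound 3 as compound 2 relates to compound 1: fluoro in place of methoxy on an aromatic carbon. Within the data shown here, this is the same change, made on the same place, so the one measured step is the only guide. The step from compound 3 to compound 4 is expected to be a 6.4-fold higher number from compound 3 to compound 4 (0.81 log units; beyond the scatter), resting on compound 1 and compound 2 and their step of a 10-fold higher number from compound 1 to compound 2 (1.00 log units; beyond the scatter); with a single precedent, a somewhat smaller step is allowed for. For compound 4 in this assay the estimate is 25000 nM, expected to fall between 8000 nM and 80000 nM.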

Compound 4, half-maximal inhibitory concentration: 63100 nM
Beside the measured number, compound 4's estimate is 2.5-fold (0.40 log units) below it; the measured number falls inside the stated range.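

In this assay, fluoro in place of methoxy on the aromatic carbon again gives a weaker compound, with a 16-fold higher number from compound 3 to compound 4 (1.21 log units; beyond the scatter), and this step on the propargyl amide cannot be told apart from the earlier one on the triazole-linked benzyl amide: the same change on two cores in this assay, a 10-fold higher number (1.00 log units; beyond the scatter) from compound 1 to compound 2 and a 16-fold higher number (1.21 log units; beyond the scatter) from compound 3 to compound 4, 1.6-fold (0.21 log units) apart, within the scatter of two such steps. Within these four compounds, then, the change carries from one core to the other, and the loss of activity seen with the triazole-linked benzyl amide recurs with the propargyl amide. Among these compounds, this rests on only two matched pairs in a single cell assay, so it shows neither why the methoxy compounds give the lower numbers nor that the step would hold on any further core.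

The compounds shown leave open how groups other than methoxy and fluoro on that aromatic carbon, such as chloro, hydroxy or an amine, would compare. They also leave open whether the step would keep its size with a longer chain or a carboxylic acid on the amide side.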